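Methyl for Fluoro on the Smaller Ring Core

This account rests on a few compounds, and the source may have more. Where it says the series, first, only, none or still open, it means among the compounds named here.

Of the compounds shown here, three have been measured in an assay on isolated protein for binding affinity to 5-hydroxytryptamine receptor 6 (Homo sapiens); on this read-out lower numbers stand for stronger inhibition and higher numbers for weaker inhibition. Compound 1 `Cc1ccc(-c2n[nH]cc2N2CCCNCC2)cc1` gives 1320 nM, compound 2 `Fc1ccc(-c2n[nH]cc2N2CCCNCC2)cc1` gives 2290 nM, and compound 3 `Fc1ccc(-c2n[nH]cc2N2CCNCC2)cc1` gives 373 nM; compound 3 stands lowest of the three, beyond the scatter from both others. Compound 2 and compound 3 differ in their cores, and that difference is not broken down here. Compound 1 and compound 2 differ in one place (methyl in place of fluoro on an aromatic carbon), which gave a 1.7-fold lower number from compound 2 to compound 1 (0.24 log units; within the scatter). Compound 4 `Cc1ccc(-c2n[nH]cc2N2CCNCC2)cc1` is not yet measured; it differs from compound 3 by the same change (methyl in place of fluoro on an aromatic carbon). Since the step from compound 2 to compound 1 stayed within the scatter, the expected step for compound 4 is a 1.5-fold lower number from compound 3 to compound 4 (0.17 log units; within the scatter), resting on that one earlier step only. Compound 4 is therefore expected to give about 250 nM, with a likely range from 100 nM to 650 nM.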

Compound 4, inhibition constant: 653 nM
Beside the measured number, compound 4's estimate is 2.6-fold (0.42 log units) below it; measured number outside the range, above it.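

In this assay, putting methyl in place of fluoro on the core of compound 3 gave a 1.8-fold higher number from compound 3 to compound 4 (0.24 log units; within the scatter), so this step taken alone is small. Set beside the earlier step, however, the same change does not carry over unchanged from one core to the other: the same change on two cores in this assay, a 1.7-fold lower number (0.24 log units; within the scatter) from compound 2 to compound 1 and a 1.8-fold higher number (0.24 log units; within the scatter) from compound 3 to compound 4, 3.0-fold (0.48 log units) apart, beyond the scatter of two such steps. With only these two pairs, the data show that a result on one core cannot simply be copied to the other, but they do not show why the cores differ or how the change would behave on a further core.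

Still open, going by these compounds, is how other groups, such as chloro, methoxy or a nitrile, would fare at this place on either core.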